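A few compounds are considered here, and "the series" means these few. Any claim that something is new, unique, unknown or untested is made for them only; others in the source may bear on it.

Of the compounds shown here, three have numbers so far in a functional assay on NCI-H460 cells (Homo sapiens) for cytotoxicity, read by MTT assay, with a stated time of 72 h; on this read-out higher numbers stand for weaker inhibition and lower numbers for stronger inhibition. Compound 1 (`Cc1[nH]cnc1/C=c1\[nH]c(=O)/c(=C/c2cccc(C(=O)c3ccc(F)cc3)c2)[nH]c1=O`) gives 15.9 nM, compound 2 (`O=c1[nH]/c(=C\c2c[nH]cn2)c(=O)[nH]/c1=C\c1cccc(Oc2ccc(F)cc2)c1`) gives 479 nM, and compound 3 (`O=c1[nH]/c(=C\c2ccccn2)c(=O)[nH]/c1=C\c1cccc(Oc2ccc(F)cc2)c1`) gives 49.1 nM. Compound 3 therefore holds the middle place, with the gaps to the lower number of compound 1 and the higher number of compound 2 both beyond the scatter.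

The next compound is compound 4 (`O=c1[nH]/c(=C\c2cccs2)c(=O)[nH]/c1=C\c1cccc(Oc2ccc(F)cc2)c1`), and the change is thiophen-2-yl in place of pyridin-2-yl on a double-bonded chain carbon bound to an aromatic carbon. For the measured compounds named here, only one measured step bears on this place: a 9.8-fold lower number from compound 2 to compound 3 (0.99 log units; beyond the scatter), with pyridin-2-yl in place of 1H-imidazol-4-yl. That modest step shows that the group at this place can move the number in this assay. Going by the values given here, it gives no direct reading for thiophen-2-yl, which no measured compound carries, so no direction can be carried over with confidence.

The estimated step is a 1.2-fold lower number from compound 3 to compound 4 (0.09 log units; within the scatter), and no change beyond the scatter is expected. For compound 4 the expected value is 40 nM, with an estimated range of 14 nM to 120 nM.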

Compound 4, half-maximal inhibitory concentration: > 1000 nM
Compound 4: no number, only a limit (the forecaster's own chance of this, stated with the estimate: 2%); middle value at least 25-fold (1.39 log units) away from the limit.
By their numbers in this assay, from the lowest: compound 1; then compound 3; then compound 2. At a limit, above all of these: compound 4.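

In this assay compound 4 gives > 1000 nM, which is a limit of the assay and not a number: the limit of > 1000 nM in this assay, at which 1 of the 4 values shown sits. Thiophen-2-yl in place of pyridin-2-yl on a double-bonded chain carbon bound to an aromatic carbon gives an at least 20-fold higher number from compound 3 to compound 4 (1.30 log units; beyond the scatter), so exchanging one aromatic ring for another with the same counts of hydrogen-bond donors and acceptors can produce a large step at this place. Thiophen-2-yl in place of 1H-imidazol-4-yl gives an at least 2.0-fold higher number from compound 2 to compound 4 (0.31 log units; beyond the scatter), which puts thiophen-2-yl at the high end of the three groups compared here.

From the compounds shown here alone, the full size of both steps stays open. Also open, going by these compounds, is whether phenyl, pyridin-3-yl or pyridin-4-yl at this place would read close to compound 3 or close to compound 4.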